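Carbamoyl for Carboxy on the Side Chain of Compound 2

A few compounds are considered here, and "the series" means these few. Any claim that something is new, unique, unknown or untested is made for them only; others in the source may bear on it.

Measured in a functional assay on the whole organism (Tail, strain ICR) with Mus musculus as the target, in the tail flick test, with a stated time of 90 min, at a dose of 25 umol/kg by the oral route; a lower number here means a weaker effect, a higher number a stronger effect of the compound at the dose given:
compound 1 `CC(C)[C@H](NC(=O)CN(c1nc(Cl)nc2[nH]cnc12)C1CC1)C(=O)OCc1ccccc1`: 51.3%
compound 2 `O=C(O)CC[C@H](NC(=O)CN(c1nc(Cl)nc2[nH]cnc12)C1CC1)C(=O)O`: 44.7%

Compound 2 gives a number that lies within the scatter of the value of compound 1, so the two cannot be told apart on these figures. Compound 3 `NC(=O)CC[C@H](NC(=O)CN(c1nc(Cl)nc2[nH]cnc12)C1CC1)C(=O)O` has not yet been measured in this assay. It differs from compound 2 by amino in place of hydroxy on a carbonyl carbon. For the measured compounds named here, no measured pair shows this change, so there is no step to lean on. The change is expected to give a step of a number 0.3 percentage points higher from compound 2 to compound 3 (within the scatter) in this assay that stays within the scatter, with no clear direction. Compound 3 is thus estimated at 45%, between 30% and 60%.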

Compound 3, a percentage reported as activity, at one dose (the size of the read-out at that dose, not a potency): 41.1%
The estimate for compound 3 lay 3.9 percentage points above the measured number; the range from low to high includes it.
By their numbers in this assay, from the lowest: compounds 3, 2 and 1 (each within the scatter of the next, the first and the last beyond it).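

In this assay, for the compounds shown here, the exchange of carboxy for carbamoyl on the side chain gives a number 3.6 percentage points lower from compound 2 to compound 3 (within the scatter) and is the first step that can be read at this position. The free carboxy on this chain is therefore not shown to be required for the read-out at this dose. Nothing available explains why the number stays within the scatter. Going by these compounds, what a primary amine, a methyl ester or a longer chain would give in place of the 2-carbamoylethyl group remains open.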